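A few compounds are considered here, and "the series" means these few. Any claim that something is new, unique, unknown or untested is made for them only; others in the source may bear on it.

Of the compounds shown here, three from this series have been measured in a functional assay (brain) for inhibition, with Rattus norvegicus as the target; on this read-out lower numbers stand for stronger inhibition and higher numbers for weaker inhibition. Compound 1 `CCN(CC)c1ccc(N2CCN(C(=O)C3(C)CCc4c(C)c(O)c(C)c(C)c4O3)CC2)nc1N(CC)CC` gives 200 nM, compound 2 `Cc1c(C)c2c(c(C)c1O)CCC(C)(C(=O)NCc1cccnc1)O2` gives 47000 nM, and compound 3 `CCNc1cccnc1N1CCN(CC2(C)CCc3c(C)c(O)c(C)c(C)c3O2)CC1` gives 1000 nM. Among these three numbers compound 3 stands second highest: its gap to compound 1 lies beyond the scatter, as does its much wider gap to compound 2. Compound 4 `Cc1c(C)c2c(c(C)c1O)CCC(C)(CN1CCN(c3ncccn3)CC1)O2` has not yet been measured in this assay. It differs from compound 3 in one place: pyrimidin-2-yl in place of 3-(ethylamino)pyridin-2-yl on an amine nitrogen in a ring. The ring that enters is smaller and brings no hydrogen-bond donor, whereas the ring that leaves carries one. Going by the values given here, no measured pair in this set shows the effect of such an exchange directly, so the expectation leans on the spread between compound 3 and the others alone. A step toward weaker inhibition is expected, a 3.0-fold higher number from compound 3 to compound 4 (0.48 log units; beyond the scatter), of a size that goes beyond the scatter but stays well short of the gap to compound 2. Compound 4 is therefore estimated at 3000 nM in this assay, within a range from 700 nM to 15000 nM.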

Compound 4, half-maximal inhibitory concentration: 1000 nM
For compound 4 the middle estimate is 3.0-fold (0.48 log units) above the measured one, and the stated range covers the measured number.
By their numbers in this assay, from the lowest: compound 1; then compounds 3 and 4 (each within the scatter of the next); then compound 2.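

In this assay, going by these compounds alone, the exchange of 3-(ethylamino)pyridin-2-yl for pyrimidin-2-yl on an amine nitrogen in a ring gives no change at the digits printed from compound 3 to compound 4 (within the scatter), the only step that can be read at this position. On this core, then, the 3-(ethylamino)pyridin-2-yl group with its hydrogen-bond donor is not needed to hold the value, and the smaller pyrimidin-2-yl serves equally well within the scatter. Nothing measured here accounts for why the two groups read alike.

The compounds shown leave open whether a phenyl ring or a methoxy-bearing pyridin-2-yl on that nitrogen would also read alike. They also leave open whether pyrimidin-2-yl would behave the same way on the carbonyl-linked piperazine of compound 1, which differs from compound 3 in more than one place.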